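From allyl to 3-fluorobenzyl on the shared core

The source may hold more compounds than are shown below. What is called first, only, known or untested is meant among the compounds shown, and "the series" means these compounds.

In a functional assay on J774.A1 cells (Mus musculus) for inhibition, read by Griess assay, with stated times of 1 h and 24 h (a lower number here means a stronger inhibitor, a higher number a weaker inhibitor), compound 1 (`CC(C)CCOc1ccccc1C1CC(=O)c2ccccc2O1`) gives 42600 nM and compound 2 (`CCCOc1ccccc1C1CC(=O)c2ccccc2O1`) gives 44600 nM while compound 3 (`C=CCOc1ccccc1C1CC(=O)c2ccccc2O1`) gives 38600 nM so compound 3 sits within the scatter of both others. Compound 4 (`O=C1CC(c2ccccc2OCc2cccc(F)c2)Oc2ccccc21`) carries 3-fluorophenyl in place of vinyl on a saturated chain carbon bound to an oxygen on an aromatic ring. Two measured steps changed this same carbon: a 1.2-fold lower number from compound 2 to compound 3 (0.06 log units; within the scatter) and a 1.1-fold lower number from compound 1 to compound 3 (0.04 log units; within the scatter) are both within the scatter. Neither brought in a ring, so they are only a thin guide. No step beyond the scatter is expected, and the estimated change is a 1.3-fold lower number from compound 3 to compound 4 (0.11 log units; within the scatter) with wide margins. Compound 4 is estimated at 30000 nM with a likely range from 12000 nM to 70000 nM in this measurement.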

Compound 4, half-maximal inhibitory concentration: 13200 nM
For compound 4 the middle estimate is 2.3-fold (0.36 log units) above the measured one, and the stated range covers the measured number.
By their numbers in this assay, from the lowest: compound 4; then compounds 3, 1 and 2 (each within the scatter of the next).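

Unlike the changes among the three open chains, replacing them with a ring moves the number beyond the scatter in this assay: allyl to 3-fluorobenzyl gives (a 2.9-fold lower number from compound 3 to compound 4 (0.47 log units; beyond the scatter)), and the matching changes give (a 3.4-fold lower number from compound 2 to compound 4 (0.53 log units; beyond the scatter)) and (a 3.2-fold lower number from compound 1 to compound 4 (0.51 log units; beyond the scatter)). So this position does respond to its substituent, though the gain is modest. Nothing measured here explains why. Plain benzyl, without the fluorine, would help separate the effect of the ring from that of the fluorine. From the compounds shown here alone, how an amine or a carboxylic acid on that ring would behave also remains open.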